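A Single Aryl Change Between Compound 3 and Compound 4

This account rests on a few compounds, and the source may have more. Where it says the series, first, only, none or still open, it means among the compounds named here.

Measured so far:
Compound 1 `Cc1cc(NC(=O)Cn2nnc(-c3ccccc3)n2)n(C2CCC(F)(F)CC2)n1` gives 68%.
Compound 2 `Cc1nc(-c2ccccc2)c(NC(=O)Cn2nnc(-c3ccccc3)n2)s1` gives "not active" (no number reported).
Compound 3 `Cc1cc(NC(=O)Cn2nnc(-c3cccnc3)n2)n(C2CCCCC2)n1` gives 96%.

These three compounds were tested in an assay on HEK293 cells for activation of Kir3.1/Kir3.2 (Homo sapiens), read by thallium flux; a lower number here means a smaller maximal response, a higher number a larger maximal response. Compound 3 stands highest of the two numbers reported; compound 1 gives 68%, which is lower by more than the usual scatter of this assay. Compound 2 has no single number, only a report of no activity.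

Compound 4 `Cc1cc(NC(=O)Cn2nnc(-c3ccc(C(F)(F)F)cc3)n2)n(C2CCCCC2)n1` is the next compound to be measured. It differs from compound 3 in one place only: 4-(trifluoromethyl)phenyl in place of pyridin-3-yl on an aromatic carbon. Within the data shown here, no pair of measured compounds differs in a single place, so no measured step shows what such a swap does here. Among the measured compounds shown here, the only guidance is that compound 3 sits near the top of the scale, leaving more room to fall than to rise. For compound 4, a modest drop is expected, as the step of a number 16 percentage points lower from compound 3 to compound 4 (beyond the scatter) shows, though a result within the scatter of compound 3 cannot be ruled out. Compound 4 is therefore estimated at 80%, in a range from 45% to 110%.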

Compound 4, largest response reached (Emax), in percent of the reference or control that the assay uses: 94%
The estimate for compound 4 lay 14 percentage points below the measured number; low and high end bracket the measured number.
By their numbers in this assay, from the lowest: compound 1; then compounds 4 and 3 (each within the scatter of the next).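

In this assay, placing 4-(trifluoromethyl)phenyl instead of pyridin-3-yl on the aromatic carbon of the five-membered ring with 4 nitrogen gives a number 2 percentage points lower from compound 3 to compound 4 (within the scatter), so the two compounds cannot be told apart by their largest response. At this position, then, a high response does not depend on the ring nitrogen or the single hydrogen-bond acceptor of pyridin-3-yl, and a group of 10 heavy atoms serves as well as one of 6, at least with the cyclohexyl group present in both compounds. No measurement here explains why the two aryl groups read alike.

As far as these compounds go, only these two aryl groups can be compared directly at this position, so the limits of this freedom remain unknown. A group without an aromatic ring, such as a simple methyl, or an aryl group carrying an amine or a carboxylic acid, could give a quite different response.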